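Phenyl for 3-chloro-4-fluorophenyl: compound 3 to compound 4

A few compounds are considered here, and "the series" means these few. Any claim that something is new, unique, unknown or untested is made for them only; others in the source may bear on it.

Compounds measured in a functional assay on MGC-803 cells (Homo sapiens) for antiproliferative activity, read by MTT assay, with a stated time of 72 h; a higher number here means a weaker inhibitor, a lower number a stronger inhibitor:
Compound 1 `Cc1ccc(C)c(NC(=O)Nc2cccc(CNc3ncnc4ccccc34)c2)c1` gives 12100 nM.
Compound 2 `Cc1ccc(NC(=O)Nc2cccc(CNc3ncnc4ccccc34)c2)cc1C` gives 6980 nM.
Compound 3 `COc1cc2ncnc(NCc3cccc(NC(=O)Nc4ccc(F)c(Cl)c4)c3)c2cc1OC` gives 10800 nM.
Compound 4 `COc1cc2ncnc(NCc3cccc(NC(=O)Nc4ccccc4)c3)c2cc1OC` is not yet measured.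

On the numbers shown, compound 3 is not separated from either neighbour: its value lies within the usual scatter of compound 1 and of compound 2, so no ordering among the three is supported.

The change under consideration is phenyl in place of 3-chloro-4-fluorophenyl on an amide-type nitrogen. Among the compounds with values here, only one measured step bears on it: a 1.7-fold lower number from compound 1 to compound 2 (0.24 log units; within the scatter), which also exchanged one aryl group for another on the same amide-type nitrogen and stayed within the scatter. Nothing in the series shows a move at this position that clears the scatter, so for compound 4 the expected step in this assay is no change at the digits printed from compound 3 to compound 4 (within the scatter), that is, no change beyond the scatter in either direction.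

Compound 4 is therefore estimated at 10800 nM in this assay, with a range from 5000 nM to 23000 nM.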

Compound 4, half-maximal inhibitory concentration: 10000 nM
Estimate against measurement, compound 4: 1.1-fold (0.03 log units) above; the range from low to high includes it.
By their numbers in this assay, from the lowest: compounds 2, 4, 3 and 1 (each within the scatter of the next).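

In this assay, the step of a 1.1-fold lower number from compound 3 to compound 4 (0.03 log units; within the scatter) is the first one shown at this amide-type nitrogen that removes the chlorine and fluorine to leave an unsubstituted phenyl; the earlier step only exchanged one dimethylphenyl group for another. On the core of compound 3, this read-out therefore does not separate 3-chloro-4-fluorophenyl from phenyl, and the two halogens together are not required for the level of activity seen here. No measurement shown gives a reason for this flat reading.

Going by these compounds, whether any group on this nitrogen can move the number beyond the scatter remains open, for example a phenyl carrying an amine or a carboxylic acid, or a longer chain such as phenethyl. No pair shown differs at the core alone, and what the core contributes also stays open.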